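A few compounds are considered here, and "the series" means these few. Any claim that something is new, unique, unknown or untested is made for them only; others in the source may bear on it.

Measured compounds in a functional assay on ACHN cells (Homo sapiens) for cytotoxicity, read by sulforhodamine B assay, with a stated time of 48 h; on this read-out higher numbers stand for weaker inhibition of growth and lower numbers for stronger inhibition of growth:
- compound 1, `ClCc1cccc(Cn2cnc3c(Cl)nc(Cl)nc32)c1`: 3710 nM
- compound 2, `ClCc1ccccc1Cn1cnc2nc(Cl)nc(Cl)c21`: 1250 nM
- compound 3, `ClCc1ccc(Cn2cnc3c(Cl)nc(Cl)nc32)cc1`: 5250 nM

Among the three, compound 2 gives the lowest number in this assay; compound 1 and compound 3 both give higher numbers, and each of those gaps lies beyond the usual scatter of the read-out. The three share a core and differ in where the chloromethyl group sits on the benzyl ring.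

Compound 4, `ClCc1ccccc1Cn1cnc2ncnc(Cl)c21`, has not yet been measured. Against compound 2 it shows one change: hydrogen in place of chloro on an aromatic carbon. Among the measured compounds shown here, no pair of measured compounds differing only in this way is available, so the size of the step is not known from the set.

The expectation is that compound 4 gives a somewhat higher number than compound 2, a step of a 2.4-fold higher number from compound 2 to compound 4 (0.38 log units; beyond the scatter), of a size clearly beyond the scatter though not large. Compound 4 is therefore estimated at 3000 nM in this assay, with a range from 1000 nM to 9000 nM.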

Compound 4, concentration for total growth inhibition: 4260 nM
Estimate against measurement, compound 4: 1.4-fold (0.15 log units) below; the measured number falls inside the stated range.
By their numbers in this assay, from the lowest: compound 2; then compounds 1, 4 and 3 (each within the scatter of the next).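

In this assay the step of a 3.4-fold higher number from compound 2 to compound 4 (0.53 log units; beyond the scatter) is modest but beyond the scatter, so the chloro group between two ring nitrogen atoms contributes to the read-out and is not a silent part of the shared core. Among the compounds shown here, the earlier compounds varied only in where the chloromethyl group sits on the benzyl ring, and this is the first step to show a change on the core itself. The data give no measured basis for explaining the step.

As far as these compounds go, it remains open whether an amine, a methoxy group or a methyl group at this position would match the chloro group or hydrogen. Also open, from the compounds shown here alone, is whether the same step would appear with the chloromethyl group placed as in compound 1 or compound 3.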